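A few compounds are considered here, and "the series" means these few. Any claim that something is new, unique, unknown or untested is made for them only; others in the source may bear on it.

The measured compounds:
compound 1, `Cc1nnc(-c2nsc3ccccc23)o1`: 43%
compound 2, `CCc1nnc(-c2nsc3ccccc23)o1`: 10%

Both were tested in a functional assay on the whole organism for inhibition, with Rattus norvegicus as the target, with a stated time of 2 h, at a dose of 100 mg/kg by the oral route; on this read-out lower numbers stand for less inhibition and higher numbers for more inhibition at the one dose given (going by the name of the read-out). Compound 2 stands lowest of the two numbers; its nearest neighbour is compound 1, which is higher by a gap beyond the scatter. Going by the values given here, the one measured step touching compound 2 is a number 33 percentage points lower from compound 1 to compound 2 (beyond the scatter), where the change was methyl in place of hydrogen on a saturated chain carbon bound to an aromatic carbon: a large fall.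

Compound 3, `c1ccc(-c2nnc(-c3nsc4ccccc34)o2)cc1`, has not been measured. It differs from compound 2 by phenyl in place of ethyl on an aromatic carbon, on an aromatic carbon of the five-membered aromatic ring with 2 nitrogen and 1 oxygen. Among the compounds with values here, no measured step puts a ring in this place, so the only guide is that the single measured step went down as the group grew, and a still larger group is not expected to recover what was lost. The expected step of a number 5 percentage points higher from compound 2 to compound 3 (within the scatter) is therefore small, within the scatter. Compound 3 is estimated at 15%, with a range from 0% to 40%.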

Compound 3, a percentage reported as inhibition, in the whole organism at one dose (the size of the read-out at that dose, not a potency): 60%
Compound 3: middle estimate off by 45 percentage points, on the low side; the whole stated range lies below it.
By their numbers in this assay, from the lowest: compound 2; then compound 1; then compound 3.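

On an aromatic carbon of the five-membered aromatic ring with 2 nitrogen and 1 oxygen, replacing ethyl with phenyl in this assay gives a number 50 percentage points higher from compound 2 to compound 3 (beyond the scatter). Replacing methyl with phenyl at the same place gives a number 17 percentage points higher from compound 1 to compound 3 (beyond the scatter), so this position can carry an aromatic ring with a higher number than either small chain, and the fall from methyl to ethyl is no rule for every larger group here. Nothing available explains why phenyl behaves so differently from the two chains.

The compounds shown leave open whether the aromatic ring itself matters or whether a saturated ring such as cyclohexyl would serve as well. They also leave open how a longer chain such as propyl, an amine or a pyridine ring would read at this position.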